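From Chloro to Carboxy: What Compound 4 Might Show

The source may report more compounds than this note shows. Statements on the series, on what has been measured and on what is new or still open speak of the compounds shown alone.

Compound 1 `CC1(C)Oc2ccc(C#N)cc2[C@@H](/N=C(\NC#N)Nc2ccc(Cl)cc2)[C@@H]1O` was tested in a functional assay (aorta) with Rattus norvegicus as the target (on this read-out higher numbers stand for weaker inhibition and lower numbers for stronger inhibition), where compound 1 gives 1800 nM. Among the three compounds measured so far, this is the second highest number. Compound 2 `CC1(C)Oc2ccc(C#N)cc2[C@@H](NC(=O)Nc2cccnc2)[C@@H]1O` gives 500 nM in this assay, a lower number that lies beyond the usual scatter, so compound 2 is the stronger inhibitor of the two. Compound 3 `CC1(C)Oc2ccc(C#N)cc2[C@@H](N2CCN(c3ccccc3)C2=O)[C@@H]1O` gives 23700 nM in this assay, a higher number than compound 1, again beyond the scatter, so compound 3 inhibits more weakly. Compounds 2 and 3 each differ from compound 1 in more than one place, so neither provides a single-change step to lean on.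

Compound 4 `CC1(C)Oc2ccc(C#N)cc2[C@@H](/N=C(\NC#N)Nc2ccc(C(=O)O)cc2)[C@@H]1O` has not yet been measured. It differs from compound 1 in one place: carboxy in place of chloro on an aromatic carbon. Among the measured compounds shown here, no pair of measured compounds shows this change, so the size of the step cannot be read from any measured pair. The expectation is a moderate step toward a higher number, that is weaker inhibition, described by a 5.6-fold higher number from compound 1 to compound 4 (0.74 log units; beyond the scatter). On that basis compound 4 is estimated at 10000 nM, with a plausible range from 2500 nM to 40000 nM.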

Compound 4, half-maximal inhibitory concentration: > 100000 nM
Compound 4: no number, only a limit; the forecaster's own chance of this, stated with the estimate: 15%; middle value at least 10-fold (1.00 log units) away from the limit.
By their numbers in this assay, from the lowest: compound 2; then compound 1; then compound 3. At a limit, above all of these: compound 4.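

In this assay, the aromatic carbon para to a large group proves highly sensitive to what it carries: carboxy in place of chloro gives an at least 55-fold higher number from compound 1 to compound 4 (1.74 log units; beyond the scatter). Among the compounds shown here, compounds 2 and 3 each differ from compound 1 in more than one place, so they could not isolate this carbon; this pair changes only that one group, with the rest of the core of compound 1 kept, and so gives the first direct view of this position. Compound 4 gives > 100000 nM, which is a limit of the assay and not a number, so the step sets a minimum size and does not fix the true one: the limit of > 100000 nM in this assay, at which 1 of the 4 values shown sits.

One pair cannot show which difference between chloro and carboxy matters, whether the extra heavy atoms, the double bond or the added hydrogen-bond donor and acceptor. A methyl ester or a primary amide at the same carbon could begin to separate these, and a methyl group or an amine there would show whether this carbon tolerates anything other than chloro.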